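Working notes: bromo to acetamido on the shared core

The compounds below may be only part of what the source reports. "The series", "measured", "known", "first", "only" and "open" are said of these compounds alone.

In a functional assay on SMMC-7721 cells (Homo sapiens) for cytotoxicity, read by MTT assay, with a stated time of 24 h (a lower number here means a stronger inhibitor, a higher number a weaker inhibitor), compound 1 `O=C1/C(=C/c2ccncc2)CN(S(=O)(=O)c2ccccc2)C/C1=C\c1ccccc1F` gives 17500 nM and compound 3 `O=C1/C(=C/c2ccncc2)CN(S(=O)(=O)c2ccc(Br)cc2)C/C1=C\c1ccccc1F` gives 12600 nM as a value within the scatter of the other. Compound 2 `O=C1/C(=C/c2ccncc2)CN(S(=O)(=O)c2ccc(F)cc2)C/C1=C\c1ccccc1F` reads > 20000 nM as a limit of the assay, not a number. The change to compound 4 `CC(=O)Nc1ccc(S(=O)(=O)N2C/C(=C\c3ccncc3)C(=O)/C(=C/c3ccccc3F)C2)cc1` is acetamido in place of bromo on an aromatic carbon with acetamido in place of bromo on an aromatic carbon. Among the measured compounds shown here, two steps bear on it: a 1.4-fold lower number from compound 1 to compound 3 (0.14 log units; within the scatter) for bromo in place of hydrogen and an at least 1.5-fold lower number from compound 2 to compound 3 (0.20 log units; that floor lies within the scatter) for bromo in place of fluoro, the second being only a floor. For the measured compounds named here, no measured step involves acetamido. No step beyond the scatter is therefore expected in this assay in either direction. The expected step is a 1.1-fold higher number from compound 3 to compound 4 (0.05 log units; within the scatter) and stays within the scatter. For compound 4 the estimated value is 14000 nM within a range of 7000 nM to 20000 nM on present data.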

Compound 4, half-maximal inhibitory concentration: 13400 nM
Beside the measured number, compound 4's estimate is 1.0-fold (0.02 log units) above it, and the stated range covers the measured number.
By their numbers in this assay, from the lowest: compounds 3, 4 and 1 (each within the scatter of the next). At a limit, above all of these: compound 2.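

In this assay the 4-acetamidophenyl group carries a hydrogen-bond donor, where 4-bromophenyl has none, yet the steps at this position stay small (a 1.1-fold higher number from compound 3 to compound 4 (0.03 log units; within the scatter)) and (a 1.3-fold lower number from compound 1 to compound 4 (0.12 log units; within the scatter)). The comparison with the fluoro compound reads (an at least 1.4-fold lower number from compound 2 to compound 4 (0.17 log units; that floor lies within the scatter)), which is only a floor. Compound 2 stands at a limit of the assay, not a number: the limit of > 20000 nM in this assay, at which 1 of the 4 values shown sits.

Still open, from the compounds shown here alone, is whether an amine or a carboxylic acid at this position would give a step beyond the scatter. A longer chain on the amide nitrogen leaves the same question.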